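Three compounds at the assay limit, a fourth to measure

This account rests on a few compounds, and the source may have more. Where it says the series, first, only, none or still open, it means among the compounds named here.

Compound 1 `COc1nc(N)nc2c1c(-c1ccoc1)cn2[C@@H]1O[C@H](CO)[C@@H](O)[C@H]1O`, compound 2 `Nc1nc(N)c2c(-c3ccoc3)cn([C@@H]3O[C@H](CO)[C@@H](O)[C@H]3O)c2n1` and compound 3 `Nc1nc(N)c2c(-c3cc4ccccc4o3)cn([C@@H]3O[C@H](CO)[C@@H](O)[C@H]3O)c2n1` share one core and were tested in a functional assay on HeLa S3 cells (Homo sapiens) for antiproliferative activity, read by XTT assay, with a stated time of 72 h; a higher number here means a weaker inhibitor, a lower number a stronger inhibitor. Compound 1 gives only a limit there, > 20000 nM. Compound 2 likewise gives only a limit, > 20000 nM. Compound 3 also gives only a limit, > 20000 nM. Compound 1 differs from compound 2 by methoxy in place of amino on an aromatic carbon, and the step is a step that the two limits leave unreadable from compound 2 to compound 1. Compound 3 differs from compound 2 by 1-benzofuran-2-yl in place of furan-3-yl on an aromatic carbon, a step that the two limits leave unreadable from compound 2 to compound 3. Every value here sits at the limit of > 20000 nM in this assay, at which 3 of the 3 values shown sit.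

Compound 4 `COc1nc(N)nc2c1c(-c1cc3ccccc3o1)cn2[C@@H]1O[C@H](CO)[C@@H](O)[C@H]1O` is still to be measured in this assay. Among the measured compounds shown here, it differs from compound 3 by methoxy in place of amino on an aromatic carbon, the same change as the one from compound 2 to compound 1, made on the core of compound 3, which differs from that of compound 2 by 1-benzofuran-2-yl in place of furan-3-yl on an aromatic carbon. For compound 4 the expected step is a step that the limit leaves unreadable from compound 3 to compound 4. This rests on compound 3 giving only a limit, > 20000 nM. It rests also on the earlier step that the two limits leave unreadable from compound 2 to compound 1 being unreadable. Compound 4 is therefore estimated at 30000 nM, between 12000 nM and 100000 nM, most likely reported again as a limit.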

Compound 4, half-maximal inhibitory concentration: > 20000 nM
Compound 4 was reported as a limit; the forecaster's own chance of this, stated with the estimate: 88%; the middle value lies beyond the limit too.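

In this assay compound 4 gives > 20000 nM, which is a limit, so no step can be read from compound 3 or compound 1 to compound 4. All the values shown stand at one limit: the limit of > 20000 nM in this assay, at which 4 of the 4 values shown sit.

The compounds shown leave open how strong any of them is, and whether either change shifts antiproliferative activity at all.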